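A few compounds are considered here, and "the series" means these few. Any claim that something is new, unique, unknown or untested is made for them only; others in the source may bear on it.

In a functional assay on SiHa cells (Homo sapiens) for inhibition (on this read-out lower numbers stand for stronger inhibition and higher numbers for weaker inhibition), compound 1 `COc1cc(/C=C/C(=O)c2cccc(NC(=O)c3ccco3)c2)ccc1O` gives 0.76 ug/mL. Compound 2 `CCOC(=O)C(=O)Nc1cccc(C(=O)/C=C/c2ccc(O)c(OC)c2)c1` gives > 50 ug/mL, and this is a limit of the assay, not a number. Its place on the scale is known only as the limit of > 50 ug/mL in this assay, at which 1 of the 2 values shown sits. Among the measured compounds shown here, the one measured step, an at least 65-fold higher number from compound 1 to compound 2 (1.81 log units; beyond the scatter), came with ethoxycarbonyl taking the place of furan-2-yl on a carbonyl carbon.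

Compound 3 `COc1cc(/C=C/C(=O)c2cccc(NC(C)=O)c2)ccc1O` changes that carbonyl carbon again: methyl in place of ethoxycarbonyl on a carbonyl carbon. Here methyl takes the place of ethoxycarbonyl, so the group that came in with the large measured step leaves again. For the measured compounds named here, that single step is the only evidence bearing on this change. A large move toward a lower number in this assay, meaning stronger inhibition, is therefore expected. Methyl is not furan-2-yl, however, so a full return to the 0.76 ug/mL of compound 1 is not assumed. The expected size is an at least 6.2-fold lower number from compound 2 to compound 3 (0.79 log units; beyond the scatter). This remains uncertain because compound 2 gives only the limit > 50 ug/mL. For compound 3 the estimate is 8 ug/mL, with an expected range of 1.5 ug/mL to 45 ug/mL.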

Compound 3, half-maximal inhibitory concentration: 15.8 ug/mL
Beside the measured number, compound 3's estimate is 2.0-fold (0.30 log units) below it; measured number inside the range.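

In this assay, methyl in place of ethoxycarbonyl on this carbonyl carbon gives a clear gain in inhibition, with an at least 3.1-fold lower number from compound 2 to compound 3 (0.50 log units; beyond the scatter). The value of compound 2 is a limit and not a number, so this step gives only the smallest size the change can have: the limit of > 50 ug/mL in this assay, at which 1 of the 3 values shown sits. Methyl does not recover what furan-2-yl gave, with a 21-fold higher number from compound 1 to compound 3 (1.32 log units; beyond the scatter), so this one place separates all three groups, with furan-2-yl in compound 1 giving the lowest number, methyl in compound 3 a middle one and ethoxycarbonyl in compound 2 the weakest read-out.

From the compounds shown here alone, what a phenyl ring, a thiophene ring or a longer chain such as propyl would give on this carbonyl carbon stays open, so these compounds cannot tell whether any ring would serve here or furan-2-yl in particular is needed. Going by these compounds, it is also open how a carboxylic acid or a simple amine in this place would compare with ethoxycarbonyl and methyl on the same core.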